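Extending the diamine chain on compound 3

The compounds below may be only part of what the source reports. "The series", "measured", "known", "first", "only" and "open" are said of these compounds alone.

Compound 3 `NCC(N)CC(=O)N1CCN(C(=O)CCn2cccc(O)c2=O)CC1` was studied in a physicochemical assay, read by spectrophotometry, with a stated time of 10 min, tested at 200 uM, in the presence of a further agent that is not named here (a higher number here means a stronger effect of the compound at the concentration tested, a lower number a weaker effect), together with compound 2 `NCC(N)CCCCNC(=O)c1cc(O)c(O)c(O)c1` and compound 1 `COc1cc(/C=C/C(=O)NCCCCC(N)CN)ccc1O`. In this assay compound 2 gives 87.4%, while compound 3 gives 50.3%, the lower of the two numbers, lying a gap beyond the usual scatter below compound 2. For compound 1 the result in this assay is recorded as "not determined" (no result reported), so no number is available for it.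

Compound 4 `NCC(N)CCC(=O)N1CCN(C(=O)CCn2cccc(O)c2=O)CC1` has not yet been measured in this assay. It differs from compound 3 in a single place: 2,3-diaminopropyl in place of 1,2-diaminoethyl on a saturated chain carbon bound to a carbonyl carbon. The part of the molecule that carries the hydroxypyridinone remains unchanged.

Within the data shown here, no measured pair shows how lengthening the diamine chain by one carbon alters the read-out in this assay, so no direction can be read from the known compounds. Compound 4 is therefore expected to give a result close to that of compound 3, with the expected step being a number 0.3 percentage points lower from compound 3 to compound 4 (within the scatter), which lies within the scatter. The estimate for compound 4 in this assay is 50%, with a range from 35% to 65%.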

Compound 4, a percentage reported as activity, at one concentration (the size of the read-out at that concentration, not a potency): 53.2%
The estimate for compound 4 lay 3.2 percentage points below the measured number; the measured number falls inside the stated range.
By their numbers in this assay, from the lowest: compounds 3 and 4 (each within the scatter of the next); then compound 2.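

In this assay, among these compounds, the only measured step at this place, 2,3-diaminopropyl in place of 1,2-diaminoethyl on a saturated chain carbon bound to a carbonyl carbon, comes to a number 2.9 percentage points higher from compound 3 to compound 4 (within the scatter), with the part carrying the hydroxypyridinone unchanged. This read-out therefore does not separate the two diamine chains, and compound 3 and compound 4 stand level within the scatter. Nothing available accounts for this result.

On these data alone, whether a 3,4-diaminobutyl group or a longer chain at this place would stay level with compound 4 remains open, as does the outcome with a single amine or a carboxylic acid there. Compound 2 differs from compound 4 in more than one place, so the compounds shown do not tell what the part carrying the hydroxypyridinone contributes to the read-out.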